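Compound 3: the hydroxy form of compound 2

A few compounds are considered here, and "the series" means these few. Any claim that something is new, unique, unknown or untested is made for them only; others in the source may bear on it.

Compound 1 `N#Cc1ncc2nc1OCC/C=C\COc1ccc(Cl)cc1NC(=O)N2`: > 10000 nM
Compound 2 `N#Cc1ncc2nc1OCC/C=C\COc1ccc(CCOC3CCCCO3)cc1NC(=O)N2`: > 10000 nM

In a functional assay on NCI-H1299 cells (Homo sapiens), read by flow cytometry (a lower number here means that less compound is needed, a higher number that more compound is needed for the effect), compound 1 reads > 10000 nM, which is a limit and not a number. Compound 2 reads > 10000 nM, which is also a limit. Compound 2 therefore has no number of its own, and all that can be said is the limit of > 10000 nM in this assay, at which 2 of the 2 values shown sit.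

Compound 3 `N#Cc1ncc2nc1OCC/C=C\COc1ccc(CCO)cc1NC(=O)N2` differs from compound 2 in one place: hydrogen in place of oxan-2-yl on an oxygen on a saturated carbon. Hydrogen takes the place of oxan-2-yl on an oxygen on a saturated carbon, so that 2-((oxan-2-yl)oxy)ethyl becomes 2-hydroxyethyl.

Going by the values given here, only one measured step bears on this change: a step that the two limits leave unreadable from compound 1 to compound 2. It brought in the group now being cut back, but it has no readable size, so it offers no size or direction to carry over. With nothing to suggest a large move, a reading at or close to the limit is expected, and another limit is about as likely as a number. The estimate amounts to an expected at least 1.2-fold lower number from compound 2 to compound 3 (0.09 log units; that floor lies within the scatter). For compound 3 the expected value in this assay is 8000 nM, with an estimated range of 2500 nM to 20000 nM.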

Compound 3, half-maximal effective concentration: > 10000 nM
Compound 3 was reported as a limit; the forecaster's own chance of this, stated with the estimate: 55%; at least 1.2-fold (0.09 log units) between middle value and limit.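

In this assay compound 3 reads > 10000 nM, which is a limit and not a number. Going by these compounds alone, no step among compound 1, compound 2 and compound 3 can be read, and the three share one limit: the limit of > 10000 nM in this assay, at which 3 of the 3 values shown sit. The compounds shown leave open whether any group in this place gives a readable value in this assay.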